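The source may report more compounds than this note shows. Statements on the series, on what has been measured and on what is new or still open speak of the compounds shown alone.

Values in a functional assay on A549 cells (Homo sapiens) for antiproliferative activity, read by MTT assay, with a stated time of 48 h; a higher number here means a weaker inhibitor, a lower number a stronger inhibitor:
- Compound 1 `C/C(=C\CC/C(C)=C/CC[C@@H]1[C@@]2(C)CCC(=O)C(C)(C)[C@H]2CC[C@@]1(C)O)CC/C=C(\C)C(=O)OCc1cn(-c2ccc(F)c(Cl)c2)nn1`: > 150000 nM, a limit and not a number.
- Compound 2 `C/C(=C\CC/C(C)=C/CC[C@@H]1[C@@]2(C)CCC(=O)C(C)(C)[C@H]2CC[C@@]1(C)O)CC/C=C(\C)C(=O)OCc1cn(C[C@@H]2O[C@H](n3ccc(=O)[nH]c3=O)C[C@H]2O)nn1`: 28100 nM.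
- Compound 3 `C/C(=C\CC/C(C)=C/CC[C@@H]1[C@@]2(C)CCC(=O)C(C)(C)[C@H]2CC[C@@]1(C)O)CC/C=C(\C)C(=O)OCc1cn(-c2ccccc2C)nn1`: > 150000 nM, a limit and not a number.

Compound 1 has no numerical position in the series, only a limit: its entry is the limit of > 150000 nM in this assay, at which 2 of the 3 values shown sit. Compound 4 `C/C(=C\CC/C(C)=C/CC[C@@H]1[C@@]2(C)CCC(=O)C(C)(C)[C@H]2CC[C@@]1(C)O)CC/C=C(\C)C(=O)OCc1cn(-c2cccc(Cl)c2)nn1` changes 3-chloro-4-fluorophenyl to 3-chlorophenyl, with hydrogen in place of fluoro on an aromatic carbon, ortho to a chloro group and para to a large group (hydrogen in place of fluoro on an aromatic carbon).

For the measured compounds named here, the one measured step bearing on this is a step that the two limits leave unreadable from compound 1 to compound 3, with 2-methylphenyl in place of 3-chloro-4-fluorophenyl on an aromatic nitrogen. It gives no size to carry over, and it does not touch the fluoro position alone. No shift beyond the scatter is therefore expected in this assay, and no direction can be assigned. The expected change is a number no higher from compound 1 to compound 4 (the limit leaves the size open), and a report as a limit is the likeliest outcome. For compound 4 the estimate is 150000 nM, with an expected range of 60000 nM to 300000 nM.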

Compound 4, half-maximal inhibitory concentration: 147000 nM
Compound 4: middle estimate off by 1.0-fold (0.01 log units), on the high side; the range from low to high includes it.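

In this assay, compound 4 gives 147000 nM, a measured number rather than a limit, and hydrogen in place of fluoro on this aromatic carbon reads as an at least 1.0-fold lower number from compound 1 to compound 4 (0.00 log units; that floor lies within the scatter). The change of 2-methylphenyl to 3-chlorophenyl on the aromatic nitrogen reads as an at least 1.0-fold lower number from compound 3 to compound 4 (0.00 log units; that floor lies within the scatter). Neither step is shown to go beyond the scatter, and each gives only a floor, with its full size unreadable from a limit: the limit of > 150000 nM in this assay, at which 2 of the 4 values shown sit.

On these data alone, it remains open whether an amine or a carboxylic acid in place of fluoro on this aromatic carbon would move the number in this assay beyond the scatter. As far as these compounds go, it also remains open whether a methoxy group there would do so.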